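The compounds below may be only part of what the source reports. "The series", "measured", "known", "first", "only" and "open" are said of these compounds alone.

Measured so far:
- compound 1, `CC(C)CCn1c(=O)c2nc[nH]c2n(CC(C)C)c1=O`: 13000 nM in an assay on cell membranes for antagonist activity at adenosine receptor A1 (Rattus norvegicus); on this read-out lower numbers stand for stronger inhibition and higher numbers for weaker inhibition
- compound 2, `Cn1c(=O)c2nc(-c3cccc(N)c3)[nH]c2n(C)c1=O`: 1100 nM in this assay

Compound 1 carries the highest number of the two in this assay; compound 2 sits at a lower number, and the gap between the two values lies beyond the usual scatter. The two compounds differ in more than one place, so their values are only compared as they stand, without a counted step between them.

Compound 3, `CC(C)CCn1c(=O)c2nc(-c3ccccc3)[nH]c2n(CC(C)C)c1=O`, is not yet measured in this assay. It arises from compound 1 through one change, (phenyl in place of hydrogen on an aromatic carbon). The remainder of the core of compound 1 is kept, including both chains on the ring nitrogens.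

Among the compounds with values here, no pair of measured compounds differing only in this way is available, so the size of the step rests on expectation alone. The step from compound 1 to compound 3 is expected to run toward lower numbers, that is toward stronger inhibition, and to be clearly larger than the scatter: a 22-fold lower number from compound 1 to compound 3 (1.34 log units; beyond the scatter). For compound 3 the estimate in this assay is 600 nM, with a likely range from 100 nM to 3000 nM.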

Compound 3, inhibition constant: 1800 nM
The estimate for compound 3 lay 3.0-fold (0.48 log units) below the measured number; low and high end bracket the measured number.
By their numbers in this assay, from the lowest: compounds 2 and 3 (each within the scatter of the next); then compound 1.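

In this assay, phenyl in place of hydrogen on an aromatic carbon between two ring nitrogen atoms gives a 7.2-fold lower number from compound 1 to compound 3 (0.86 log units; beyond the scatter), a modest step but one beyond the scatter. Within the data shown here, with both chains on the ring nitrogens kept, this is the one comparison that isolates this position, and it shows that this carbon can carry a ring rather than only hydrogen without loss of inhibition. The entering ring is of carbon only and counts no hydrogen-bond donors or acceptors, so in this pair the lower number arises without either in the new group, while no measurement at hand accounts for the size of the step or its cause.

Still open, as far as these compounds go, is whether a cyclopentyl group or a smaller methyl group on this carbon gives a step of similar size, and whether a carboxylic acid or a methoxy group on the phenyl ring moves the number further in either direction. Also open, from the compounds shown here alone, is whether the step keeps its size with other chains on the ring nitrogens, such as propyl.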